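A few compounds are considered here, and "the series" means these few. Any claim that something is new, unique, unknown or untested is made for them only; others in the source may bear on it.

Measured compounds in a functional assay on M14 cells (Homo sapiens) for cytotoxicity, read by resazurin assay, with a stated time of 72 h; a higher number here means a weaker inhibitor, a lower number a stronger inhibitor:
- compound 1 `COc1cc(/C=C/C(=O)OC(C)CCOc2no[n+]([O-])c2S(=O)(=O)c2ccccc2)ccc1O` gives 410 nM.
- compound 2 `O=C(/C=C/c1ccc(OCCCCCO[N+](=O)[O-])c(O)c1)OCCCCCO[N+](=O)[O-]` gives only a limit, > 50000 nM.
- compound 3 `COc1cc(/C=C/C(=O)Oc2ccc(OCc3c(-c4ccccc4)no[n+]3[O-])cc2)ccc1O` gives only a limit, > 50000 nM.

Compound 2 thus stands at the edge of what this assay reports: no number, only a limit, and it shares this position with the limit of > 50000 nM in this assay, at which 2 of the 3 values shown sit. For the measured compounds named here, no measured pair differs in a single place, so no step size is known from the data.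

Compound 4 `COc1cc(/C=C/C(=O)OCCCCCO[N+](=O)[O-])ccc1OCCCCCO[N+](=O)[O-]` differs from compound 2 by methyl in place of hydrogen on an oxygen on an aromatic ring. Given the limit of compound 2 at > 50000 nM, a step of a number no higher from compound 2 to compound 4 (the limit leaves the size open) is expected, that is, no change beyond the scatter; most likely compound 4 also returns only a limit. For compound 4 the estimate is 50000 nM, within 15000 nM to 100000 nM.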

Compound 4, half-maximal inhibitory concentration: > 50000 nM
Compound 4 gave a limit, no number; the forecaster's own chance of this, stated with the estimate: 70%; the middle value sits exactly at the limit.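

Compound 2 gives only a limit, > 50000 nM. Compound 4 also gives only a limit, > 50000 nM, so no step can be read between the two. The compounds shown leave open what hydroxy to methoxy does when both partners give a number in this assay.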